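This account rests on a few compounds, and the source may have more. Where it says the series, first, only, none or still open, it means among the compounds named here.

Compounds measured so far:

Compound 1 `Cc1ccc(NC(=O)[C@H](CC2CCCC2)NC(=O)c2cc(Cl)ccc2O)cc1` gives in a functional assay on K562 cells (Homo sapiens) for cytotoxicity, with a stated time of 72 h (on this read-out lower numbers stand for stronger inhibition and higher numbers for weaker inhibition), the value > 10000 nM, which is a limit of the assay and not a number. Compound 2 `CC(C)(C)[C@H](NC(=O)c1cc(Cl)ccc1O)C(=O)Nc1cccc(C(F)(F)F)c1` gives 5900 nM in this assay. Compound 3 `O=C(N[C@@H](CC1CCCCC1)C(=O)Nc1cccc(C(F)(F)F)c1)c1cc(Cl)ccc1O` gives 3400 nM in this assay.

Compound 3 holds the lower of the two numbers, with compound 2 nearest: a 1.7-fold lower number from compound 2 to compound 3 (0.24 log units; within the scatter). Compound 4 `O=C(N[C@@H](CC1CCCCC1)C(=O)Nc1ccc(Br)cc1)c1cc(Cl)ccc1O` differs from compound 3 by 4-bromophenyl in place of 3-(trifluoromethyl)phenyl on an amide-type nitrogen. For the measured compounds named here, no measured step changes the group on this amide-type nitrogen; compound 1 carries a different group there, but also differs elsewhere and gives only a limit, so it offers no guidance. Going by the values given here, the only measured step, a 1.7-fold lower number from compound 2 to compound 3 (0.24 log units; within the scatter), concerns another part of the molecule. For compound 4 an estimated step of no change at the digits printed from compound 3 to compound 4 (within the scatter) is expected, nothing beyond the scatter. Compound 4 is therefore estimated at 3400 nM, within 1000 nM to 12000 nM.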

Compound 4, half-maximal inhibitory concentration: 3000 nM
Compound 4: the middle estimate sits 1.1-fold (0.05 log units) above what was measured; the range from low to high includes it.
By their numbers in this assay, from the lowest: compounds 4, 3 and 2 (each within the scatter of the next). At a limit, above all of these: compound 1.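

In this assay, for the compounds shown here, the only measured change on the amide-type nitrogen, 4-bromophenyl in place of 3-(trifluoromethyl)phenyl, gives a 1.1-fold lower number from compound 3 to compound 4 (0.05 log units; within the scatter) and so shows that these two aryl groups cannot be told apart here. This holds with the cyclohexylmethyl chain and the rest of the molecule kept the same. Nothing measured here bears on why the two groups read alike. Still open, as far as these compounds go, is whether an amine or a carboxylic acid on this phenyl ring, or a longer chain in place of the ring, would move the number beyond the scatter.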